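The source may hold more compounds than are shown below. What is called first, only, known or untested is meant among the compounds shown, and "the series" means these compounds.

Of the compounds shown here, three have so far been tested in an ADME assay on Vero cells (Chlorocebus sabaeus) for cytotoxicity; on this read-out higher numbers stand for lower toxicity in this test and lower numbers for higher toxicity in this test. Compound 2 (`Fc1ccc(-c2nc3ccc(Br)cn3c2-c2ccnc(NC3CCCC3)n2)cc1`) reads > 40000 nM, which is a limit and not a number. Compound 3 (`Fc1ccc(-c2nc3c(Br)cc(Br)cn3c2-c2ccnc(NC3CCCC3)n2)cc1`) reads > 40000 nM, again a limit. It therefore stands at the limit of > 40000 nM in this assay, at which 2 of the 3 values shown sit. Among the measured compounds shown here, the only true number comes from compound 1 (`CCCCNc1cccn2c(-c3ccnc(NC4CCCC4)n3)c(-c3ccc(F)cc3)nc12`), which carries a butylamino group and gives 32000 nM.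

Compound 4 (`CCCCNc1cc(Br)cn2c(-c3ccnc(NC4CCCC4)n3)c(-c3ccc(F)cc3)nc12`) differs from compound 3 by one change, butylamino in place of bromo on an aromatic carbon. For the measured compounds named here, the only measured step is a step that the two limits leave unreadable from compound 2 to compound 3, for bromo in place of hydrogen on an aromatic carbon, and it offers no size to carry over. Compound 4 shares the butylamino group with the best guide, compound 1, which gives 32000 nM. On that basis, the read-out is expected to move towards lower numbers, and the estimated change is an at least 1.5-fold lower number from compound 3 to compound 4 (0.18 log units; that floor lies within the scatter). For compound 4 the expected value is 26000 nM, within an estimated range of 11000 nM to 50000 nM.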

Compound 4, half-maximal cytotoxic concentration: > 40000 nM
Compound 4: a limit, no number; the forecaster's own chance of this, stated with the estimate: 35%; at least 1.5-fold (0.18 log units) between middle value and limit.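

In this assay compound 4 gives > 40000 nM, which is a limit and not a number. Among the compounds shown here, the one readable step, bromo in place of hydrogen on an aromatic carbon, is an at least 1.2-fold higher number from compound 1 to compound 4 (0.09 log units; that floor lies within the scatter), so adding this bromo to the butylamino compound cannot be told apart from no change at all. Compounds 2, 3 and 4 end at the same limit, and the steps among them cannot be read: the limit of > 40000 nM in this assay, at which 3 of the 4 values shown sit.

From the compounds shown here alone, how far compounds 2, 3 and 4 lie beyond that limit remains open, so the effect of swapping bromo for butylamino at this place has no size yet. Also open, going by these compounds, is whether a different group here, such as a shorter chain, a cyclic amine or a carboxylic acid, would give a true number in this test.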